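The source may hold more compounds than are shown below. What is called first, only, known or untested is meant among the compounds shown, and "the series" means these compounds.

Compound 1 `O=C1O[C@H]([C@@H](O)Cn2cc(-c3cccc(O)c3)nn2)C(OCc2ccccc2)=C1OCc1ccccc1` and compound 2 `COc1ccccc1-c1cn(C[C@H](O)[C@H]2OC(=O)C(OCc3ccccc3)=C2OCc2ccccc2)nn1` share the same core and differ only in the group carried on an aromatic carbon of the five-membered ring. In a functional assay on CFPAC-1 cells (Homo sapiens) for antiproliferative activity, read by MTT assay, with a stated time of 72 h (a higher number here means a weaker inhibitor, a lower number a stronger inhibitor), compound 1 gives 54100 nM. In this assay compound 2 reaches only a limit of the assay, > 100000 nM, and not a number. That places compound 2 at the limit of > 100000 nM in this assay, at which 1 of the 2 values shown sits, so its position is known only as a boundary. Going by the values given here, the single measured comparison, an at least 1.8-fold higher number from compound 1 to compound 2 (0.26 log units; that floor lies within the scatter), therefore says only that swapping one aromatic group for another did not shift the number beyond the usual scatter.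

Compound 3 `CCCCCCCCCCc1cn(C[C@H](O)[C@H]2OC(=O)C(OCc3ccccc3)=C2OCc2ccccc2)nn1` keeps everything in compound 2 apart from one change: decyl in place of 2-methoxyphenyl on an aromatic carbon. Among the compounds with values here, no measured step exchanges an aromatic group for an open chain, so the one measured step is a loose guide at best. The step of an at least 1.2-fold lower number from compound 2 to compound 3 (0.09 log units; that floor lies within the scatter) is expected to be modest, with a fair chance that the assay again reports only a limit. In this assay compound 3 is expected to give about 80000 nM, within a likely range from 25000 nM to 100000 nM.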

Compound 3, half-maximal inhibitory concentration: 40300 nM
Estimate against measurement, compound 3: 2.0-fold (0.30 log units) above; low and high end bracket the measured number.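

In this assay, going by these compounds alone, an at least 2.4-fold lower number from compound 2 to compound 3 (0.39 log units; beyond the scatter) is the first step at this position that goes beyond the scatter, and it shows that decyl, an open chain with no ring, can stand on this aromatic carbon of the five-membered ring and still give a measured number. With a 1.3-fold lower number from compound 1 to compound 3 (0.13 log units; within the scatter), the step stays within the scatter, so decyl and 3-hydroxyphenyl cannot be told apart here, and a six-membered aromatic ring at this position is not needed for compound 3 to reach the level of compound 1. The first step is only a floor, and its true size stays unknown, as compound 2 stands at a limit of the assay and not at a number: the limit of > 100000 nM in this assay, at which 1 of the 3 values shown sits.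

The compounds shown leave open whether the length of the chain matters, which a shorter chain such as butyl or a longer chain such as dodecyl would test. They also leave open whether a chain ending in an amine or a carboxylic acid would move the number beyond the scatter from where compound 3 stands.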